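This account rests on a few compounds, and the source may have more. Where it says the series, first, only, none or still open, it means among the compounds named here.

Compound 1 `Clc1ccc(-c2cc(-c3cccnc3)nc(-c3cccs3)c2)o1` gives 25.8% in an assay on isolated protein for inhibition of DNA topoisomerase 1 (Homo sapiens), tested at 100 uM (on this read-out higher numbers stand for a stronger effect at the one concentration tested and lower numbers for a weaker effect), and stands highest of the three compounds measured there. Compound 2 `Cc1ccc(-c2cc(-c3ccoc3)cc(-c3ccsc3)n2)cc1` gives 13.2% in this assay, lower than compound 1 beyond the scatter, and compound 3 `Clc1ccc(-c2cc(-c3cccnc3)nc(-c3ccsc3)c2)o1` gives 0%, the furthest from compound 1. Within the data shown here, the only measured step between compounds differing in one place is a number 25.8 percentage points lower from compound 1 to compound 3 (beyond the scatter), where thiophen-3-yl replaces thiophen-2-yl on an aromatic carbon.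

Compound 4 `Clc1cccc(-c2cc(-c3ccc(Cl)o3)cc(-c3cccs3)n2)c1` differs from compound 1 in one place: 3-chlorophenyl in place of pyridin-3-yl on an aromatic carbon. Among the measured compounds shown here, no measured step bears on this exchange of pyridin-3-yl for 3-chlorophenyl; the single step on record concerns another group on the shared core, so it gives no direction for this change. The expectation for this assay is therefore a step of modest size in either direction, possibly none beyond the scatter, and compound 4 is estimated at 18%, within a range from 0% to 40%. This corresponds to an expected step of a number 7.8 percentage points lower from compound 1 to compound 4 (within the scatter).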

Compound 4, a percentage reported as inhibition, at one concentration (the size of the read-out at that concentration, not a potency): 42%
Compound 4: middle estimate off by 24 percentage points, on the low side; the measured number lies above the stated range.
By their numbers in this assay, from the lowest: compound 3; then compound 2; then compound 1; then compound 4.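

In this assay, among these compounds, the place next to the ring nitrogen, which no earlier step had touched, tolerates a change and even gains from it: 3-chlorophenyl in place of pyridin-3-yl gives a number 16.2 percentage points higher from compound 1 to compound 4 (beyond the scatter). Among the compounds shown here, the only earlier step, at the thiophene, went the other way, so compound 4 shows that the shared core can also move upward on this read-out. The exchange removes the pyridine nitrogen and adds a chlorine together, and nothing measured on these compounds accounts for the rise.

On these data alone, it remains open whether the gain comes with the carbon-only ring alone, as a plain phenyl would show, or needs the chlorine, and how a methoxy group or an amine in that chlorine's place would read. Also open, as far as these compounds go, is whether thiophen-3-yl would lower compound 4 as it lowered compound 1.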